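A thiophen-3-yl swap at the assay limit

The source may report more compounds than this note shows. Statements on the series, on what has been measured and on what is new or still open speak of the compounds shown alone.

Compound 1 `CS(=O)(=O)c1ccc(-c2nc3ccccn3c2Sc2ccccc2)cc1`: > 100000 nM (a limit)
Compound 2 `C(=C/c1nc2ccccn2c1Sc1ccccc1)\c1ccccc1`: > 100000 nM (a limit)
Compound 3 `Cc1ccc(-c2nc3ccc(C)cn3c2Sc2ccccc2)cc1`: > 100000 nM (a limit)

All three readings come from an ADME assay on HEK293 cells (Homo sapiens) for inhibition, read by MTT assay, with a stated time of 48 h; on this read-out lower numbers stand for stronger inhibition and higher numbers for weaker inhibition. Compound 2 stands with the other two at the limit of > 100000 nM in this assay, at which 3 of the 3 values shown sit, so it has no exact number. Compound 4 `c1ccc(Sc2c(-c3ccsc3)nc3ccccn23)cc1` carries thiophen-3-yl in place of 2-phenylethenyl on an aromatic carbon. Within the data shown here, no two measured compounds differ in one place, so no measured step guides this change. Compound 2 gives > 100000 nM as a limit, so no step beyond the scatter is expected in this assay. The estimated a number no higher from compound 2 to compound 4 (the limit leaves the size open) is expected to stay small. For compound 4 the estimate is 100000 nM, with an expected range from 30000 nM to 300000 nM.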

Compound 4, half-maximal inhibitory concentration: 91700 nM
The estimate for compound 4 lay 1.1-fold (0.04 log units) above the measured number, and the stated range covers the measured number.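

In this assay, thiophen-3-yl in place of 2-phenylethenyl at this position gives an at least 1.0-fold lower number from compound 2 to compound 4 (0.03 log units; that floor lies within the scatter). Compound 4 gives 91700 nM, the first exact number among the compounds shown, so a reading inside the range of the assay is possible with this group here. The true size of the step cannot be read because the starting value is not an exact number: the limit of > 100000 nM in this assay, at which 3 of the 4 values shown sit.

From the compounds shown here alone, whether an amine or a carboxylic acid at this position would shift the number further remains open. So does whether a change to the phenylsulfanyl group would do so.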